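Benzyl for Hydroxyphenyl on Silicon: Expected Recovery

The source may report more compounds than this note shows. Statements on the series, on what has been measured and on what is new or still open speak of the compounds shown alone.

Compound 2 `CCN(C/C=C/C#CC(C)(C)C)Cc1cccc(OC[Si](C)(C)c2ccc(O)cc2)c1` gives 8000 nM in a functional assay on liver (Sus scrofa) for inhibition of squalene monooxygenase (Homo sapiens), using microsomes (on this read-out lower numbers stand for stronger inhibition and higher numbers for weaker inhibition), the higher of the two measured numbers. Among the compounds with values here, compound 1 `CCN(C/C=C/C#CC(C)(C)C)Cc1cccc(OC[Si](C)(C)c2ccc(F)cc2)c1` gives 60 nM, and the only measured step is a 130-fold higher number from compound 1 to compound 2 (2.12 log units; beyond the scatter). Compound 3 `CCN(C/C=C/C#CC(C)(C)C)Cc1cccc(OC[Si](C)(C)Cc2ccccc2)c1` differs from compound 2 by benzyl in place of 4-hydroxyphenyl on a silicon, which takes away the hydroxy that had entered in that step. Because that step was a 130-fold higher number from compound 1 to compound 2 (2.12 log units; beyond the scatter), compound 3 is expected to show a large fall in this assay, a 53-fold lower number from compound 2 to compound 3 (1.73 log units; beyond the scatter). Compound 3 is therefore estimated at 150 nM, with a range from 40 nM to 600 nM.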

Compound 3, half-maximal inhibitory concentration: 130 nM
Beside the measured number, compound 3's estimate is 1.2-fold (0.06 log units) above it; measured number inside the range.
By their numbers in this assay, from the lowest: compound 1; then compound 3; then compound 2.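

In this assay, replacing the hydroxyphenyl group gives a 62-fold lower number from compound 2 to compound 3 (1.79 log units; beyond the scatter) and shows that this position on the silicon accepts a benzyl group, with its ring held one carbon further out and no hydrogen-bond donor or acceptor. The recovery is incomplete, since the comparison with the fluorinated compound gives a 2.2-fold higher number from compound 1 to compound 3 (0.34 log units; beyond the scatter) and leaves compound 1 with the lowest number of the three. Still open, from the compounds shown here alone, is how a plain phenyl, a 4-fluorobenzyl or a 4-hydroxybenzyl group on the silicon would compare, which would separate the effect of the added carbon from that of the ring substituent. No available evidence explains either step.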